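The compounds below may be only part of what the source reports. "The series", "measured", "known", "first", "only" and "open" are said of these compounds alone.

Of the compounds shown here, three from one series have been tested in a functional assay on HT-29 cells (Homo sapiens) for cytotoxicity, read by XTT assay, with a stated time of 72 h; a lower number here means a stronger inhibitor, a higher number a weaker inhibitor. Compound 1 `C=C1CC[C@H]2C(C)(C)CCC[C@]2(C)[C@H]1CC/C(C)=C/COc1cc(O)c2c(=O)c(O)c(-c3ccc(OC)cc3)oc2c1` was measured first in this assay and gives only a limit of the assay, > 100000 nM, not a number. Compound 3 `C=C1CC[C@H]2C(C)(C)CCC[C@]2(C)[C@H]1CC/C(C)=C/COc1cc(O)c2c(=O)c(O)c(-c3ccc(O)cc3)oc2c1` also gives only a limit in this assay, > 100000 nM. Compound 3 differs from compound 1 by hydrogen in place of methyl on an oxygen on an aromatic ring, and the step that the two limits leave unreadable from compound 1 to compound 3 cannot be read because of the limit of > 100000 nM in this assay, at which 3 of the 3 values shown sit. Compound 2 `C=C1CC[C@H]2C(C)(C)CCC[C@]2(C)[C@H]1CC/C(C)=C/COc1cc(O)c2c(=O)c(OC/C=C(\C)CC[C@H]3C(=C)CC[C@H]4C(C)(C)CCC[C@]34C)c(-c3ccc(OC)cc3)oc2c1` likewise gives only a limit in this assay, > 100000 nM; how its core differs from that of compound 1 is not broken down here.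

Compound 4 `C=C1CC[C@H]2C(C)(C)CCC[C@]2(C)[C@H]1CC/C(C)=C/COc1cc(O)c2c(=O)c(OC/C=C(\C)CC[C@H]3C(=C)CC[C@H]4C(C)(C)CCC[C@]34C)c(-c3ccc(O)cc3)oc2c1` has not yet been measured in this assay. Among the compounds with values here, it differs from compound 2 by hydrogen in place of methyl on an oxygen on an aromatic ring, the same change as the one from compound 1 to compound 3. On that change the step from compound 1 to compound 3 stayed at the limit, so compound 4 is expected to stay there too, with a step that the limit leaves unreadable from compound 2 to compound 4 that is itself no more than an expectation. Compound 4 is therefore estimated at 150000 nM, within a range of 50000 nM to 500000 nM.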

Compound 4, half-maximal inhibitory concentration: > 100000 nM
Compound 4 gave a limit, no number (the forecaster's own chance of this, stated with the estimate: 85%); the middle value lies beyond the limit too.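

Compound 2 and compound 4 both give only a limit and not a number, so no step can be read between them, because all the results shown sit at that limit: the limit of > 100000 nM in this assay, at which 4 of the 4 values shown sit. The compounds shown leave open how strongly any of them acts in this assay, and whether going from methoxy to hydroxy changes that at all.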